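Replacing the acid of compound 3 with a pyrrolidine amide

The source may report more compounds than this note shows. Statements on the series, on what has been measured and on what is new or still open speak of the compounds shown alone.

compound 1, `FC(F)(F)c1ccc(Nc2ncnc3sc(Nc4c(Cl)cccc4Cl)nc23)cc1`: 3 nM
compound 2, `CSc1ccc(Nc2ncnc3sc(Nc4c(Cl)cccc4Cl)nc23)cc1`: 12 nM
compound 3, `O=C(O)c1ccc(Nc2ncnc3sc(Nc4c(Cl)cccc4Cl)nc23)cc1`: > 5000 nM

In a functional assay on HEK293 cells for antagonist activity at transient receptor potential cation channel subfamily V member 1 (Rattus norvegicus), read by calcium flux (on this read-out higher numbers stand for weaker inhibition and lower numbers for stronger inhibition), compound 1 gives 3 nM and compound 2 gives 12 nM; the step of a 4.0-fold higher number from compound 1 to compound 2 (0.60 log units; beyond the scatter) is modest. For compound 3 only a limit is known, > 5000 nM, which is the limit of > 5000 nM in this assay, at which 1 of the 3 values shown sits. The steps of an at least 1600-fold higher number from compound 1 to compound 3 (3.22 log units; beyond the scatter) and an at least 410-fold higher number from compound 2 to compound 3 (2.61 log units; beyond the scatter) are both large, so compound 3 is the weakest of the three.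

Compound 4, `O=C(c1ccc(Nc2ncnc3sc(Nc4c(Cl)cccc4Cl)nc23)cc1)N1CCCC1`, differs from compound 3 by pyrrolidin-1-yl in place of hydroxy on a carbonyl carbon. Within the data shown here, the only steps that bear on it are those into compound 3, an at least 1600-fold higher number from compound 1 to compound 3 (3.22 log units; beyond the scatter) and an at least 410-fold higher number from compound 2 to compound 3 (2.61 log units; beyond the scatter), which show that the carboxy group carries the whole loss; whether the amide restores what was lost is untested, and the starting point is a limit, so the size of the return is open. The expected step is an at least 12-fold lower number from compound 3 to compound 4 (1.09 log units; beyond the scatter), toward stronger inhibition. Compound 4 is estimated at 400 nM, with a range from 40 nM to 4000 nM.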

Compound 4, half-maximal inhibitory concentration: > 5000 nM
Compound 4: only a limit was reported (the forecaster's own chance of this, stated with the estimate: 25%); middle value at least 12-fold (1.09 log units) from the limit.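

In this assay, compound 4 remains at a limit, as compound 3 does, so pyrrolidin-1-yl in place of hydroxy on the carbonyl carbon brings no readable return of inhibition: the limit of > 5000 nM in this assay, at which 2 of the 4 values shown sit.

The step between compound 3 and compound 4 cannot be read, since both values are limits. The earlier compounds shown here tied the loss to carboxy, but it persists with the hydroxy gone, as (pyrrolidin-1-yl)carbonyl on this aromatic carbon gives an at least 410-fold higher number from compound 2 to compound 4 (2.61 log units; beyond the scatter) and an at least 1600-fold higher number from compound 1 to compound 4 (3.22 log units; beyond the scatter).

On these data alone, whether an unsubstituted carboxamide, a methyl ester, a nitrile or a methylsulfonyl group at this aromatic carbon keeps inhibition in this assay remains open. As far as these compounds go, how weak compound 3 and compound 4 truly are, and whether they differ at all, also remains open.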